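This account rests on a few compounds, and the source may have more. Where it says the series, first, only, none or still open, it means among the compounds named here.

In a functional assay on the whole organism (Hindlimb, strain albino) with Mus musculus as the target, in the maximal electroshock model, with a stated time of 0.5 h (a lower number here means that less compound is needed, a higher number that more compound is needed for the effect), compound 3 (`CC(=O)N1N=C(Nc2nc3ccccc3s2)CC1OC1=CC=C1`) gives 382 umol/kg and holds the highest number of the three measured compounds. Compound 1 (`CC(=O)N1N=C(Nc2nc3ccc(Cl)cc3s2)CC1c1ccccc1`) gives 161 umol/kg and compound 2 (`CC(=O)N1N=C(Nc2nc3ccc(C)cc3s2)CC1OC1=CC=C1`) gives 160 umol/kg and these two values lie within the scatter of each other.

Compound 4 (`CC(=O)N1N=C(Nc2nc3ccc(Cl)cc3s2)CC1OC1=CC=C1`) differs from compound 3 by chloro in place of hydrogen on an aromatic carbon with chloro in place of hydrogen on an aromatic carbon. Among the measured compounds shown here, the only measured step at this carbon is a 2.4-fold higher number from compound 2 to compound 3 (0.38 log units; beyond the scatter) with hydrogen in place of methyl on an aromatic carbon. Read in reverse, this modest step suggests that a group at this carbon lowers the number. Compound 1 carries the same chloro at 161 umol/kg but has a different group elsewhere on the core, so it offers only loose support. For the measured compounds named here, no measured pair isolates chloro itself.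

A modest move to a lower number is therefore expected, similar in size to the methyl step. The estimated step is a 2.2-fold lower number from compound 3 to compound 4 (0.35 log units; beyond the scatter) and remains uncertain. In this assay the expected value for compound 4 is 170 umol/kg with an estimated range (85 umol/kg to 330 umol/kg).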

Compound 4, dose for half-maximal effect: 212 umol/kg
Beside the measured number, compound 4's estimate is 1.2-fold (0.10 log units) below it; the range from low to high includes it.
By their numbers in this assay, from the lowest: compounds 2, 1, 4 and 3 (each within the scatter of the next, the first and the last beyond it).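

In this assay, chloro in place of hydrogen on the aromatic carbon gives a 1.8-fold lower number from compound 3 to compound 4 (0.26 log units; within the scatter), so a substituent at this carbon does not reliably lower the number: the methyl case, a 2.4-fold higher number from compound 2 to compound 3 (0.38 log units; beyond the scatter), clears the scatter, while the chloro case does not. Chloro and methyl cannot be told apart here, with a 1.3-fold higher number from compound 2 to compound 4 (0.12 log units; within the scatter), and with chloro held constant, the exchange of groups on the saturated ring carbon also stays unresolved, with a 1.3-fold higher number from compound 1 to compound 4 (0.12 log units; within the scatter). No measured evidence bears on the reason for these results.

On these data alone, it remains open whether a methoxy group, an amine or a carboxylic acid on this aromatic carbon would shift the number beyond the scatter. Also open, as far as these compounds go, is whether the exchange on the saturated ring carbon would read the same with methyl or hydrogen on the aromatic carbon.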